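Cytotoxicity outlook for a fluorophenyl swap on the propyl chain

The compounds below may be only part of what the source reports. "The series", "measured", "known", "first", "only" and "open" are said of these compounds alone.

This account follows a set of closely related compounds through an ADME assay on MT2 cells (Homo sapiens) for cytotoxicity, read by XTT assay, with a stated time of 4 days; on this read-out lower numbers stand for higher toxicity in this test and higher numbers for lower toxicity in this test. Compound 1, with the structure `Cc1ccc(-c2c3c(nc(C)c2C(OC(C)(C)C)C(=O)O)CCN(S(C)(=O)=O)C3)cc1`, compound 2, with the structure `Cc1ccc(CCCN2CCc3nc(C)c([C@H](OC(C)(C)C)C(=O)O)c(-c4cc(F)c5c(c4C)CCCO5)c3C2)cc1F`, and compound 3, with the structure `Cc1ccc(-c2c3c(nc(C)c2[C@H](OC(C)(C)C)C(=O)O)CCN(C(=O)NCc2ccccc2)C3)cc1`, have been measured, while compound 4, with the structure `Cc1nc2c(c(-c3cc(F)c4c(c3C)CCCO4)c1[C@H](OC(C)(C)C)C(=O)O)CN(CCCc1ccccc1F)CC2`, has not. In this assay compound 1 gives > 40000 nM, which is a limit of the assay rather than a number. Compound 2 likewise gives only a limit of the assay, > 40000 nM. Compound 3 also sits at a limit of the assay, giving > 40000 nM. So compound 2 stands where the other two stand: at the limit of > 40000 nM in this assay, at which 3 of the 3 values shown sit, and no compound in the set has yet given a number in this assay.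

Compound 4 is reached from compound 2 by one change, (2-fluorophenyl in place of 3-fluoro-4-methylphenyl on a saturated chain carbon, three bonds along the chain from an amine nitrogen in a ring). Nothing in the data ties a change of this kind to a shift in this assay, and every measured value sits at the same limit. The step from compound 2 to compound 4 is therefore expected to be none beyond the scatter, a step that the limit leaves unreadable from compound 2 to compound 4. Compound 4 is estimated to give 60000 nM, within a range from 30000 nM to 150000 nM, most likely reported again as a limit.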

Compound 4, half-maximal cytotoxic concentration: > 40000 nM
Compound 4: no number, only a limit (the forecaster's own chance of this, stated with the estimate: 85%); the middle value lies beyond the limit too.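

Compound 4, like compound 2, gives only a limit of the assay in this assay, so no step can be read between compound 2 and compound 4: the limit of > 40000 nM in this assay, at which 4 of the 4 values shown sit.

The compounds shown leave open whether 2-fluorophenyl in place of 3-fluoro-4-methylphenyl changes the cytotoxicity read-out at all, and what number any of these compounds would give.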